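The compounds below may be only part of what the source reports. "The series", "measured", "known", "first", "only" and "open" are said of these compounds alone.

Measured in a functional assay on A2780 cells (Homo sapiens) for inhibition, read by sulforhodamine B assay, with a stated time of 72 h; on this read-out lower numbers stand for stronger inhibition and higher numbers for weaker inhibition:
- Compound 1 `Cc1ccccc1S(=O)(=O)c1ccc(CNC(=O)c2cc3cnccc3[nH]2)cc1`: 13 nM
- Compound 2 `Cn1c(C(=O)NCc2ccc(S(=O)(=O)c3ccccc3)cc2)cc2cnccc21`: > 10000 nM, a limit of the assay
- Compound 3 `O=C(NCc1ccc(S(=O)(=O)c2ccccc2)cc1)c1c[nH]c2ccncc12`: 2100 nM

Compound 3 at 2100 nM is the higher of the two true numbers, and the gap to compound 1 at 13 nM lies beyond the scatter. Compound 4 `O=C(NCc1ccc(S(=O)(=O)c2ccccc2)cc1)c1cc2cnccc2[nH]1` has the same atoms as compound 3, joined differently: a group of 9 heavy atoms (7 carbon, 2 nitrogen; one five-membered aromatic ring with 1 hetero atom, one six-membered aromatic ring with 1 hetero atom) in place of a group of 9 heavy atoms (7 carbon, 2 nitrogen; one five-membered aromatic ring with 1 hetero atom, one six-membered aromatic ring with 1 hetero atom), on a carbonyl carbon, on a carbonyl carbon. The entering group also sits on the carbonyl carbon of compound 1, which gives 13 nM, so a large downward step beyond the scatter is expected in this assay. The estimated change is a 110-fold lower number from compound 3 to compound 4 (2.02 log units; beyond the scatter). For compound 4 the estimated value is 20 nM, with an expected range of 5 nM to 90 nM.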

Compound 4, half-maximal inhibitory concentration: 18 nM
Compound 4: middle estimate off by 1.1-fold (0.05 log units), on the high side, within the range that was stated.
By their numbers in this assay, from the lowest: compounds 1 and 4 (each within the scatter of the next); then compound 3. At a limit, above all of these: compound 2.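

In this assay, joining the same atoms differently on the carbonyl carbon gives a 120-fold lower number from compound 3 to compound 4 (2.07 log units; beyond the scatter), so at this place the way the group is joined counts, not only its atoms. Hydrogen in place of methyl on an aromatic carbon gives a 1.4-fold higher number from compound 1 to compound 4 (0.14 log units; within the scatter). Hydrogen in place of methyl on an aromatic nitrogen gives an at least 550-fold lower number from compound 2 to compound 4 (2.74 log units; beyond the scatter), a step read from a limit for compound 2: the limit of > 10000 nM in this assay, at which 1 of the 4 values shown sits.

Going by these compounds, how a methoxy group or a chlorine on that aromatic carbon would read stays open. So does the true number of compound 2.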